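Sulfonyl aryl replacements: isoquinoline step from compound 3

The source may hold more compounds than are shown below. What is called first, only, known or untested is meant among the compounds shown, and "the series" means these compounds.

Measured compounds in an assay on isolated protein for inhibition of B1 bradykinin receptor (Homo sapiens); on this read-out higher numbers stand for weaker inhibition and lower numbers for stronger inhibition:
compound 1 `CC(C)(C)NCc1ccc2c(c1)CCC[C@H]2NC(=O)C[C@@H]1CCCCN1S(=O)(=O)c1ccc(Cl)cc1`: 560 nM
compound 2 `Cc1ccc(S(=O)(=O)N2CCCC[C@H]2CC(=O)N[C@@H]2CCCc3cc(CNC(C)(C)C)ccc32)cc1Cl`: 15 nM
compound 3 `Cc1ccc(S(=O)(=O)N2CCCC[C@H]2CC(=O)N[C@@H]2CCCc3cc(CNC(C)(C)C)ccc32)cc1C(F)(F)F`: 11 nM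

Compound 3 shows the lowest number of the three, but compound 2 lies within the scatter of it, the step being a 1.4-fold lower number from compound 2 to compound 3 (0.13 log units; within the scatter), so no order between these two is claimed. Compound 1 stands far off: a 51-fold lower number from compound 1 to compound 3 (1.71 log units; beyond the scatter) and a 37-fold lower number from compound 1 to compound 2 (1.57 log units; beyond the scatter).

Compound 4 `CC(C)(C)NCc1ccc2c(c1)CCC[C@H]2NC(=O)C[C@@H]1CCCCN1S(=O)(=O)c1cccc2cnccc12` carries the change (isoquinolin-5-yl in place of 4-methyl-3-(trifluoromethyl)phenyl on a sulfonyl sulfur). For the measured compounds named here, no measured step covers this replacement. The two steps from compound 1 show that the group on the sulfonyl sulfur can move the number by a large amount, while the step from compound 2 to compound 3 shows a single ring substituent swap staying within the scatter. The direction for isoquinolin-5-yl cannot be read from these data. A moderate step, more likely toward a higher number, is expected: a 3.6-fold higher number from compound 3 to compound 4 (0.56 log units; beyond the scatter). Compound 4 is estimated at 40 nM, with a range from 8 nM to 250 nM.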

Compound 4, half-maximal inhibitory concentration: 610 nM
Estimate against measurement, compound 4: 15-fold (1.18 log units) below; measured number outside the range, above it.
By their numbers in this assay, from the lowest: compounds 3 and 2 (each within the scatter of the next); then compounds 1 and 4 (each within the scatter of the next).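

Isoquinolin-5-yl on the sulfonyl sulfur does not keep the low numbers of the two methyl-bearing phenyl groups (a 55-fold higher number from compound 3 to compound 4 (1.74 log units; beyond the scatter); a 41-fold higher number from compound 2 to compound 4 (1.61 log units; beyond the scatter)). It sits within the scatter of 4-chlorophenyl (a 1.1-fold higher number from compound 1 to compound 4 (0.04 log units; within the scatter)), so adding a second aromatic ring with a ring nitrogen recovers none of the large step seen with 3-chloro-4-methylphenyl and 4-methyl-3-(trifluoromethyl)phenyl. No available evidence bears on this result.

The compounds shown leave open whether the ring nitrogen or the second ring goes with the higher number. A naphthalen-1-yl group at this sulfonyl sulfur would separate the two.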